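Swapping Chloro for Fluoro on a Benzyl Group

The source may hold more compounds than are shown below. What is called first, only, known or untested is meant among the compounds shown, and "the series" means these compounds.

For the measured compounds named here, compound 2 `O=C1/C(=C/c2ccc(-c3cc(C(F)(F)F)ccc3Cl)o2)SC(=S)N1Cc1ccc(Cl)cc1` is one of two compounds measured in a functional assay on HT-29 cells (Homo sapiens) for inhibition, read by MTT assay, with a stated time of 2 days; a lower number here means a stronger inhibitor, a higher number a weaker inhibitor. In this assay compound 2 gives 8300 nM, the higher of the two numbers recorded. The other is compound 1 `O=C1N=C(Nc2ccc(F)c(Cl)c2)S/C1=C\c1ccc(-c2ccc(C(=O)O)c(O)c2)o1`, which in this assay gives 1100 nM; the gap between these two values lies beyond the usual scatter, and since the two structures differ in several places at once, no single change can be tied to that gap.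

Compound 3 `O=C1/C(=C/c2ccc(-c3cc(C(F)(F)F)ccc3Cl)o2)SC(=S)N1Cc1ccc(F)cc1` has not yet been measured. It differs from compound 2 in one place: fluoro in place of chloro on an aromatic carbon. Going by the values given here, no pair of measured compounds shows what this exchange does, so the expectation rests on the size of the change alone, which is small. The step from compound 2 to compound 3 is expected to be a 1.1-fold higher number from compound 2 to compound 3 (0.04 log units; within the scatter), not beyond the scatter in either direction. The estimate for compound 3 in this assay is therefore 9000 nM, with a likely range from 4000 nM to 20000 nM.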

Compound 3, half-maximal inhibitory concentration: 4600 nM
The estimate for compound 3 lay 2.0-fold (0.29 log units) above the measured number; low and high end bracket the measured number.
By their numbers in this assay, from the lowest: compound 1; then compounds 3 and 2 (each within the scatter of the next).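

In this assay, fluoro in place of chloro on the aromatic ring of the benzyl group gives a 1.8-fold lower number from compound 2 to compound 3 (0.26 log units; within the scatter). For the compounds shown here, this is the first pair of measured compounds that differ in one place, so it is the first direct reading of a single change. At this position, on this core, the two halogens cannot be told apart, and compound 2 and compound 3 are best read as equivalent in this test.

On these data alone, whether a larger departure at the same position, such as a methoxy group, an amine or a carboxylic acid, would shift the number beyond the scatter remains open. Why the two halogens read alike also remains open, since no other measurement here bears on that question.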